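The source may hold more compounds than are shown below. What is called first, only, known or untested is meant among the compounds shown, and "the series" means these compounds.

Working notes on the series. Among the compounds with values here, compound 3 `O=C(Nc1ccc(Cl)c(-c2nnc3c(Cl)cccn23)c1)c1ccc(Cl)cc1` supplies the only number in this set: in a functional assay on A549 cells (Homo sapiens) for antiproliferative activity, read by MTT assay, with a stated time of 72 h (a lower number here means a stronger inhibitor, a higher number a weaker inhibitor), compound 3 gives 73600 nM. Compound 1 `O=C(Nc1ccc(Cl)c(-c2nnc3c(Cl)cccn23)c1)c1ccc(F)cc1Cl` returns only a limit, > 100000 nM. Compound 2 `Cc1nc(C(=O)Nc2ccc(Cl)c(-c3nnc4c(Cl)cccn34)c2)cs1` likewise returns only a limit, > 100000 nM. Both sit at the limit of > 100000 nM in this assay, at which 2 of the 3 values shown sit. Compound 4 `Cc1cc(Cl)ccc1C(=O)Nc1ccc(Cl)c(-c2nnc3c(Cl)cccn23)c1` differs from compound 3 by methyl in place of hydrogen on an aromatic carbon. Within the data shown here, no measured step adds a methyl; the nearest are an at least 1.3-fold lower number from compound 1 to compound 3 (0.13 log units; that floor lies within the scatter), which swapped the 2-chloro-4-fluorophenyl for the 4-chlorophenyl, and an at least 1.3-fold lower number from compound 2 to compound 3 (0.13 log units; that floor lies within the scatter), both with floors inside the scatter. Compound 4 is therefore expected to show only a small step, a 1.4-fold higher number from compound 3 to compound 4 (0.13 log units; within the scatter), likely back toward the limit. For compound 4 the estimate is 100000 nM, with a range of 40000 nM to 300000 nM.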

Compound 4, half-maximal inhibitory concentration: > 100000 nM
Compound 4 ended at the assay's limit; the forecaster's own chance of this, stated with the estimate: 60%; the middle value lies on the limit itself.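

Within the data shown here, on the 4-chlorophenyl, methyl in place of hydrogen, ortho to a large group, gives in this assay an at least 1.3-fold higher number from compound 3 to compound 4 (0.13 log units; that floor lies within the scatter), the first reading at this position and no sign of a gain. As far as these compounds go, compound 4 returns only a limit of the assay, so the true size of this step is unknown, and its steps from compound 1 and compound 2 cannot be read. Compound 4 thus joins the compounds at that limit: the limit of > 100000 nM in this assay, at which 3 of the 4 values shown sit.

From the compounds shown here alone, whether an amine or a methoxy at this same position would give a lower number stays open. Among these compounds, compound 3 remains the only one with a number, so no trend across the series can be drawn.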